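Adding a pyridinylmethyl arm to the butylamino nitrogen

A few compounds are considered here, and "the series" means these few. Any claim that something is new, unique, unknown or untested is made for them only; others in the source may bear on it.

Three compounds have been measured in an assay on HEK293 cells for displacement of a labelled ligand from corticotropin-releasing factor receptor 1 (Homo sapiens); on this read-out higher numbers stand for weaker inhibition and lower numbers for stronger inhibition:
compound 1 `CCCCNc1cc(C)nc2c(-c3ccc(Cl)cc3Cl)nn(C)c12` gives 170 nM;
compound 2 `Cc1cc(N(CC(C)C)CC2CC2)c2c(n1)c(-c1ccc(Cl)cc1Cl)nn2C` gives 3.7 nM;
compound 3 `CCN(CCCOC)c1cc(C)nc2c(-c3ccc(Cl)cc3Cl)nn(C)c12` gives 12.5 nM.

Compound 1 stands highest of the three. The two measured steps away from it both turn the butylamino group into a tertiary amine, and both are large: a 46-fold lower number from compound 1 to compound 2 (1.66 log units; beyond the scatter) and a 14-fold lower number from compound 1 to compound 3 (1.13 log units; beyond the scatter). Compound 4 `CCCCN(Cc1ccncc1)c1cc(C)nc2c(-c3ccc(Cl)cc3Cl)nn(C)c12` makes the same kind of change, ((pyridin-4-yl)methyl in place of hydrogen on a nitrogen on an aromatic ring), so the nitrogen of compound 4 again carries two carbon substituents. On that basis a large step downward in this assay is expected for compound 4, of about a 14-fold lower number from compound 1 to compound 4 (1.15 log units; beyond the scatter). Compound 4 is therefore estimated at 12 nM, within a range of 3 nM to 50 nM.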

Compound 4, inhibition constant: 68 nM
For compound 4 the middle estimate is 5.7-fold (0.75 log units) below the measured one; measured number above the stated range.
By their numbers in this assay, from the lowest: compound 2; then compound 3; then compound 4; then compound 1.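

In this assay compound 4 shows that a second carbon substituent on this nitrogen does not by itself bring the number down to the level of compound 2 and compound 3: (pyridin-4-yl)methyl in place of hydrogen gives only a modest gain (a 2.5-fold lower number from compound 1 to compound 4 (0.40 log units; beyond the scatter)). Its number stands above both of theirs, so at this nitrogen the identity of the added group matters, not merely its presence. The compounds shown leave open whether the ring nitrogen of the pyridine matters, which a benzyl group on the same nitrogen would test. No evidence is available to explain this result.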